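A Fluorine Added to the Phenyl Ring of Compound 2

A few compounds are considered here, and "the series" means these few. Any claim that something is new, unique, unknown or untested is made for them only; others in the source may bear on it.

Of the compounds shown here, two have been measured so far. Compound 1 `CC[C@H](Nc1cncc(-c2ccc(O)c(OC)c2)n1)c1ccccc1` gives, in a functional assay on PC-3 cells (Homo sapiens) for cytotoxicity, read by MTT assay, with a stated time of 72 h (on this read-out higher numbers stand for weaker inhibition and lower numbers for stronger inhibition), a value of 10000 nM. Compound 2 `CCCC(Nc1cncc(-c2ccc(O)c(OC)c2)n1)c1ccccc1` gives 160 nM in this assay, the lowest of the two numbers; compound 1 stands a long way above it, well beyond the usual scatter of repeated measurements.

Compound 3 `CCCC(Nc1cncc(-c2ccc(O)c(OC)c2)n1)c1cccc(F)c1` is compound 2 with one change: fluoro in place of hydrogen on an aromatic carbon. For the measured compounds named here, no step between two measured compounds isolates this kind of change, so the expectation can rest only on compound 2 and the small size of the alteration. Because compound 2 already gives 160 nM, the step from compound 2 to compound 3 is expected to be small, in no clear direction, and likely within the scatter, a 1.1-fold lower number from compound 2 to compound 3 (0.03 log units; within the scatter). Compound 3 is therefore estimated at 150 nM in this assay, within a range from 50 nM to 500 nM.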

Compound 3, half-maximal inhibitory concentration: 600 nM
Compound 3: middle estimate off by 4.0-fold (0.60 log units), on the low side; measured number outside the range, above it.
By their numbers in this assay, from the lowest: compound 2; then compound 3; then compound 1.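

For the compounds shown here, this is the first measured step that changes one place only, and it shows that this position on the phenyl ring responds even to a single added atom. In this assay the move from phenyl to 3-fluorophenyl gives a 3.8-fold higher number from compound 2 to compound 3 (0.57 log units; beyond the scatter) and so means weaker inhibition, with one fluorine, meta to a large group, enough to carry the number beyond the scatter. No measurement available here accounts for this shift.

Going by these compounds, it remains open whether this weakening belongs to fluoro in particular or to any group placed on this carbon, a question that a chloro, a methyl or a nitrile at the same place would help to settle. Also open, on these data alone, is how fluoro would behave on another carbon of this ring.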